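Replacing the bromoethyl tail with a cyclic acetal

The source may report more compounds than this note shows. Statements on the series, on what has been measured and on what is new or still open speak of the compounds shown alone.

Measured in a functional assay on mitochondria (Cricetulus griseus) for inhibition of Monoamine oxidase (Homo sapiens), tested at 0.3 uM; on this read-out lower numbers stand for a weaker effect and higher numbers for a stronger effect at the one concentration tested:
compound 1 `CCOc1ccc2c(=O)c(-c3ccc(O)cc3)coc2c1`: 64.8%
compound 2 `O=c1c(-c2ccc(O)cc2)coc2cc(OCCCCCCBr)ccc12`: 47.2%
compound 3 `O=c1c(-c2ccc(O)cc2)coc2cc(OCCCCBr)ccc12`: 19.2%

Compound 3 stands lowest of the three in this assay; compound 2 is the nearest to it, and compound 1 the furthest away. The step to compound 4 `O=c1c(-c2ccc(O)cc2)coc2cc(OCCC3OCCCO3)ccc12` changes the tail on the oxygen-bearing chain: a group of 6 heavy atoms (4 carbon, 2 oxygen; one six-membered non-aromatic ring with 2 hetero atoms) in place of a group of 3 heavy atoms (2 carbon, 1 bromine; no ring), on a saturated chain carbon, two bonds along the chain from an oxygen on an aromatic ring.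

Among the measured compounds shown here, three measured steps bear on this tail. Lengthening it from hydrogen gave a number 17.6 percentage points lower from compound 1 to compound 2 (beyond the scatter) and a number 45.6 percentage points lower from compound 1 to compound 3 (beyond the scatter), while the step of a number 28 percentage points lower from compound 2 to compound 3 (beyond the scatter) shows the shorter bromo tail falling well below the longer one. For the measured compounds named here, no measured step introduces a ring at this place, so the size of the move is uncertain; a longer tail, as in compound 2 with 47.2%, has so far read higher than the short one of compound 3.

On that basis compound 4 is expected to give 35%, within a range of 12% to 60%, which would mean an expected step of a number 15.8 percentage points higher from compound 3 to compound 4 (beyond the scatter).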

Compound 4, a percentage reported as inhibition, at one concentration (the size of the read-out at that concentration, not a potency): 41%
For compound 4 the middle estimate is 6 percentage points below the measured one; the measured number falls inside the stated range.
By their numbers in this assay, from the lowest: compound 3; then compounds 4 and 2 (each within the scatter of the next); then compound 1.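

In this assay, the step of a number 21.8 percentage points higher from compound 3 to compound 4 (beyond the scatter) shows that a tail carrying a six-membered non-aromatic ring with 2 hetero atoms can read above the 2-bromoethyl tail at this place on the chain. Set against the longer 4-bromobutyl tail, the ring-bearing tail gives the step of a number 6.2 percentage points lower from compound 2 to compound 4 (within the scatter) and cannot be told apart from it, so a reading at this level does not depend on a bromine-bearing open chain. The step of a number 23.8 percentage points lower from compound 1 to compound 4 (beyond the scatter) shows that the ring-bearing tail still does not reach the reading of compound 1.

As far as these compounds go, whether an amine, a carboxylic acid or a five-membered acetal ring on the same chain would read differently remains open. Nothing measured here explains why the ring-bearing tail reads as it does.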